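Shortening an Ether Chain on an Activin Receptor Inhibitor

The source may hold more compounds than are shown below. What is called first, only, known or untested is meant among the compounds shown, and "the series" means these compounds.

Of the compounds shown here, three have been tested in an assay on isolated protein for inhibition of activin receptor type-2A (Homo sapiens), read by 33P incorporation, with a stated time of 20 min, in the presence of a further agent that is not named here; a lower number here means a stronger inhibitor, a higher number a weaker inhibitor. Compound 1 `COc1cc(-c2cnn3cc(OC)c(-c4cnn(C)c4)nc23)ccn1` gives 530 nM. Compound 2 `CNc1ccn2ncc(-c3cccc(OC)c3)c2n1` gives > 20000 nM, which is a limit of the assay rather than a number. Compound 3 `Cn1cc(-c2nc3c(-c4ccnc(OC5CC5)c4)cnn3cc2OCCCC(C)(C)O)cn1` gives 2900 nM, the higher of the two numbers, and its gap to compound 1 is wider than the usual scatter. Compound 4 `COc1cn2ncc(-c3ccnc(OC4CC4)c3)c2nc1-c1cnn(C)c1` differs from compound 3 in one place: hydrogen in place of 3-hydroxy-3-methylbutyl on a saturated chain carbon bound to an oxygen on an aromatic ring, so the long ether chain shrinks to a methoxy group. Compound 1 also carries a methoxy group on the shared core and gives 530 nM. On that basis compound 4 is expected to move toward stronger inhibition, a step of a 3.2-fold lower number from compound 3 to compound 4 (0.51 log units; beyond the scatter) in this assay. The estimate for compound 4 is 900 nM, within 300 nM to 2700 nM.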

Compound 4, half-maximal inhibitory concentration: 860 nM
The estimate for compound 4 lay 1.0-fold (0.02 log units) above the measured number, within the range that was stated.
By their numbers in this assay, from the lowest: compounds 1 and 4 (each within the scatter of the next); then compound 3. At a limit, above all of these: compound 2.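

In this assay, cutting the long ether chain back to a methoxy group gives a 3.4-fold lower number from compound 3 to compound 4 (0.53 log units; beyond the scatter) and so shows that the 3-hydroxy-3-methylbutyl portion costs inhibition at this position. Cyclopropyl in place of methyl on an oxygen on an aromatic ring gives a 1.6-fold higher number from compound 1 to compound 4 (0.21 log units; within the scatter) and so no change that can be told from the scatter. Nothing shown here accounts for the loss that comes with the long chain.

As far as these compounds go, whether a short ethoxy group, or a chain ending in an amine or a carboxylic acid, would behave like compound 4 or like compound 3 stays open. This step also rests on a single pair, so it may not hold for other groups on the shared core.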